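The source may report more compounds than this note shows. Statements on the series, on what has been measured and on what is new or still open speak of the compounds shown alone.

In an ADME assay on liver for metabolic stability, with Liver microsome (Homo sapiens) as the target, read by LC-MS, using microsomes (a lower number here means slower removal, a higher number faster removal of the compound), compound 1 `O=C(NCc1cc(Cl)ccc1-n1cnnn1)[C@@H]1[C@H]2C[C@H]2CN1C(=O)[C@H](O)c1ccccc1` gives 61 mL.min-1.g-1 and compound 2 `CC1(C[C@@H](O)C(=O)N2C[C@H]3C[C@H]3[C@H]2C(=O)NCc2cc(Cl)ccc2-n2cnnn2)CC1` gives 12 mL.min-1.g-1. Compound 2 holds the lower of the two numbers, and the gap to compound 1 lies beyond the scatter. Compound 3 `O=C(NCc1cc(Cl)ccc1-n1cnnn1)[C@@H]1[C@@H]2C[C@@H]2CN1C(=O)[C@H](O)c1ccccc1` departs from compound 2 by phenyl in place of (1-methylcyclopropyl)methyl on a saturated chain carbon bound to a carbonyl carbon and an oxygen on a saturated carbon. Going by the values given here, no step between measured compounds isolates this change, so the expectation rests on one imperfect comparison. Compound 1 also carries phenyl and gives 61 mL.min-1.g-1, yet it differs from compound 2 in more than one place. The expected step is a 3.8-fold higher number from compound 2 to compound 3 (0.57 log units; beyond the scatter), towards faster removal and beyond the scatter. For compound 3 the estimated value is 45 mL.min-1.g-1, with an expected range of 18 mL.min-1.g-1 to 100 mL.min-1.g-1.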

Compound 3, intrinsic clearance in microsomes: < 15 mL.min-1.g-1
Compound 3: only a limit was reported; the forecaster's own chance of this, stated with the estimate: 3%; middle value at least 3.0-fold (0.47 log units) away from the limit.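

In this assay, compound 3 gives only a limit, not a number: the limit of < 15 mL.min-1.g-1 in this assay, at which 1 of the 3 values shown sits. With phenyl held constant, the series shows an at least 4.0-fold lower number from compound 1 to compound 3 (0.60 log units; beyond the scatter), and this step can be assigned to the drawn configuration alone because of this: the fact that compounds 1 and 3 differ only in the configuration as drawn. Phenyl on this saturated chain carbon therefore does not by itself set a fast removal, and the configuration of the shared core has to be counted in any reading of this position, while the step from (1-methylcyclopropyl)methyl to phenyl cannot be read.

From the compounds shown here alone, the size of that group change remains open, as does the question of whether the configuration effect carries over to groups other than phenyl. How a cyclohexyl group or a longer alkyl chain on this carbon would read in either configuration of the core is also unresolved.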